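The compounds below may be only part of what the source reports. "The series", "measured", "known", "first", "only" and "open" are said of these compounds alone.

Compound 1 `CCNC(=O)c1ccc(COC(COCc2ccc(OC)cc2)Cn2ccnc2)cc1` and compound 2 `COc1ccc(COCC(Cn2ccnc2)OCc2ccc(C(=O)N(C)C)cc2)cc1` share one core and differ only in the amide that sits on it. In a functional assay for inhibition of Thromboxane-A synthase (Homo sapiens) (a higher number here means a weaker inhibitor, a lower number a stronger inhibitor), compound 1 gives 12400 nM, while compound 2 gives 1940 nM; that is a 6.4-fold lower number from compound 1 to compound 2 (0.81 log units; beyond the scatter). Going by the values given here, compound 2 therefore holds the lowest of the two numbers, with compound 1 as its only neighbour. Compound 3 `COc1ccc(COCC(Cn2ccnc2)OCc2ccc([S+](C)[O-])cc2)cc1` differs from compound 2 by a group of 3 heavy atoms (1 carbon, 1 oxygen, 1 sulfur; no ring) in place of a group of 5 heavy atoms (3 carbon, 1 nitrogen, 1 oxygen; no ring), on an aromatic carbon. Among the compounds with values here, the one measured step, from compound 1 to compound 2, concerns a change within the amide and not its removal, so it offers only a loose guide: it shows that this position responds to changes by modest amounts. The expected outcome for compound 3 is a small move to a higher number, a 1.5-fold higher number from compound 2 to compound 3 (0.19 log units; within the scatter), with wide uncertainty. The estimate for compound 3 in this assay is 3000 nM, expected to lie between 700 nM and 15000 nM.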

Compound 3, half-maximal inhibitory concentration: 8600 nM
Estimate against measurement, compound 3: 2.9-fold (0.46 log units) below, and the stated range covers the measured number.
By their numbers in this assay, from the lowest: compound 2; then compounds 3 and 1 (each within the scatter of the next).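

In this assay, putting the group of 3 heavy atoms in place of dimethylcarbamoyl gives a 4.4-fold higher number from compound 2 to compound 3 (0.65 log units; beyond the scatter), so this position on the aromatic ring responds to replacing the amide outright, not only to a change within it. Compound 3 also sits level with the ethylamino amide, with a 1.4-fold lower number from compound 1 to compound 3 (0.16 log units; within the scatter), which means these two different groups cannot be told apart here, while dimethylcarbamoyl stays the strongest of the three. Nothing available explains why the numbers fall this way.

Open, on these data alone, is how a carboxylic acid, a simple amine or a diethylamino amide with its longer chains would behave at this same position. Also open, as far as these compounds go, is whether any group on this ring can take the number lower than compound 2 does.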